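Cytotoxicity notes on the step from compound 2 to compound 3

A few compounds are considered here, and "the series" means these few. Any claim that something is new, unique, unknown or untested is made for them only; others in the source may bear on it.

Compound 2 `Cn1cnnc1-c1cccc(NC(=O)C2CCCN(C(=O)c3cc(C(F)(F)F)cc(C(F)(F)F)c3)C2)c1` stands level with compound 1 `COC(=O)c1cccc(NC(=O)C2CCCN(C(=O)c3cc(C(F)(F)F)cc(C(F)(F)F)c3)C2)c1` in an ADME assay on PC-3 cells (Homo sapiens) for cytotoxicity, read by WST assay, tested at 100 uM; on this read-out higher numbers stand for more inhibition at the one concentration tested (going by the name of the read-out) and lower numbers for less inhibition: compound 1 gives 0%, and compound 2 gives 0%. For the measured compounds named here, the one measured step, no change at the digits printed from compound 1 to compound 2 (within the scatter), lies within the scatter. Compound 3 `O=C(Nc1ccc(Cl)nc1)C1CCCN(C(=O)c2cc(C(F)(F)F)cc(C(F)(F)F)c2)C1` differs from compound 2 at the amide-type nitrogen: 6-chloropyridin-3-yl in place of 3-(4-methyl-4H-1,2,4-triazol-3-yl)phenyl on an amide-type nitrogen. Going by the values given here, no measured step touches the group on this nitrogen; the only step available exchanged a group on an aromatic carbon and left the read-out where it was, so it bears on the present change only loosely. With both measured compounds at the floor of the read-out and no step beyond the scatter, the expectation for compound 3 in this assay is no change beyond the scatter, no change at the digits printed from compound 2 to compound 3 (within the scatter). Compound 3 is therefore estimated at 0%, with an expected range from 0% to 15%.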

Compound 3, a percentage reported as inhibition, at one concentration (the size of the read-out at that concentration, not a potency): 25%
For compound 3 the middle estimate is 25 percentage points below the measured one; the measured number lies above the stated range.
By their numbers in this assay, from the lowest: compounds 1 and 2 (each within the scatter of the next); then compound 3.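

In this assay, for the compounds shown here, the group on the amide-type nitrogen is the first place where a change moves the read-out: 6-chloropyridin-3-yl brings a number 25 percentage points higher from compound 2 to compound 3 (beyond the scatter) in place of 3-(4-methyl-4H-1,2,4-triazol-3-yl)phenyl, and a number 25 percentage points higher from compound 1 to compound 3 (beyond the scatter) in place of 3-(methoxycarbonyl)phenyl. The two steps are the same size although different groups leave, which fits the earlier exchange of methoxycarbonyl for 4-methyl-4H-1,2,4-triazol-3-yl leaving the read-out unmoved. Nothing measured on these compounds accounts for the rise.

Each step swaps a whole group, so the ring nitrogen, the chlorine and the loss of the substituted phenyl remain unseparated. A plain phenyl, a 4-chlorophenyl or a 6-aminopyridin-3-yl on the same nitrogen would show which part goes with the higher number.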